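The source may report more compounds than this note shows. Statements on the series, on what has been measured and on what is new or still open speak of the compounds shown alone.

Measured compounds, by half-maximal effective concentration in a functional assay on HEK293 cells with D(4) dopamine receptor (Homo sapiens) as the target, read by FLIPR; on this read-out higher numbers stand for an effect only at larger amounts of compound and lower numbers for an effect already at smaller amounts:
compound 1 `O/N=C(/CCN1CCN(c2ccccn2)CC1)c1ccccc1` — 21.7 nM
compound 2 `O/N=C(/CCN1CCN(c2ccccn2)CC1)c1ccccc1Cl` — 25 nM
compound 3 `Cc1ccccc1/C(CCN1CCN(c2ccccn2)CC1)=N/O` — 4.2 nM

Compound 3 gives the lowest number of the three; compound 1 stands nearest to it and compound 2 furthest, both gaps beyond the scatter. Going by the values given here, the only single-point step among the measured compounds is a 1.2-fold higher number from compound 1 to compound 2 (0.06 log units; within the scatter), chloro in place of hydrogen on an aromatic carbon, and it stays within the scatter. Compound 1 and compound 3 differ by a methyl on the aromatic ring, and their two values lie apart by more than the scatter.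

Compound 4 `Cc1ccccc1/C(CCN1CCN(c2ccccn2)CC1)=N\O` remains to be measured in this assay. Relative to compound 3, (the two compounds have the same atoms and bonds and differ only in configuration as drawn: 1 of 1 stereo elements differ; a double bond is drawn E in compound 3 and Z in compound 4). Among the compounds with values here, no measured step concerns the drawn configuration of this double bond: the chloro step and the methyl gap both touch the aromatic ring, so neither bears on the present change. The data give no basis for a direction, and a step of uncertain sign, not far beyond the scatter, is the working expectation.

For compound 4 the estimate in this assay is 8 nM, with a range of 2 nM to 40 nM. The implied step, a 1.9-fold higher number from compound 3 to compound 4 (0.28 log units; within the scatter), is expected to be modest and open in direction.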

Compound 4, half-maximal effective concentration: 20.3 nM
Estimate against measurement, compound 4: 2.5-fold (0.40 log units) below; the measured number falls inside the stated range.
By their numbers in this assay, from the lowest: compound 3; then compounds 4, 1 and 2 (each within the scatter of the next).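

this assay records a 4.8-fold higher number from compound 3 to compound 4 (0.68 log units; beyond the scatter), a step beyond the scatter that can be set on the drawn configuration of the double bond, because nothing else in the structure changes: the fact that compounds 3 and 4 differ only in the configuration as drawn. Compound 4 carries the double bond as drawn in compounds 1 and 2, and with that configuration held the aromatic group makes no difference that can be read, with a 1.1-fold lower number from compound 1 to compound 4 (0.03 log units; within the scatter) for methyl in place of hydrogen and a 1.2-fold lower number from compound 2 to compound 4 (0.09 log units; within the scatter) for methyl in place of chloro. Among the four compounds, the methyl therefore shows no effect of its own on the Z double bond, and the lower number of compound 3 is seen only where the methyl and the E double bond occur together.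

On these data alone, the E double bond appears here only with the methyl, so whether the hydrogen and chloro compounds would shift in the same way on that switch stays open. Also open, as far as these compounds go, is how the E form would respond to a methoxy or trifluoromethyl group on the aromatic carbon, or to a longer chain in the shared core.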